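The source may report more compounds than this note shows. Statements on the series, on what has been measured and on what is new or still open speak of the compounds shown alone.

In a functional assay on the whole organism (strain Wistar) for inhibition, with Rattus norvegicus as the target, read by paw edema, with stated times of 60 min and 4 h, at a dose of 100 mg/kg by the oral route (on this read-out lower numbers stand for less inhibition and higher numbers for more inhibition at the one dose given (going by the name of the read-out)), compound 2 `CCN(CC)C(=O)CC1CCc2cc(OC)c(OC)cc21` gives 37.5%. Among the compounds with values here, the only comparator is compound 1 `CNC(=O)CC1CCc2cc(OC)c(OC)cc21`, which in this assay gives 29.7%. Within the data shown here, the step of a number 7.8 percentage points higher from compound 1 to compound 2 (within the scatter) is the one measured change on the carbonyl carbon, and the two values sit within the scatter of each other, so compound 2 cannot be set apart from compound 1 on these numbers. Compound 3 `COc1cc2c(cc1OC)C(CC(=O)NC(C)(C)C)CC2` is the next member and is not yet measured in this assay. (tert-butyl)amino in place of diethylamino on a carbonyl carbon The change again rewrites the group on the carbonyl carbon and brings back a hydrogen-bond donor, as in compound 1. Among the measured compounds shown here, the single bearing step, a number 7.8 percentage points higher from compound 1 to compound 2 (within the scatter), stayed inside the scatter, so no step beyond the scatter is expected in this assay in either direction. The expected step is a number 4.5 percentage points lower from compound 2 to compound 3 (within the scatter). Compound 3 is estimated at 33%, with a range from 18% to 48%.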

Compound 3, a percentage reported as inhibition, in the whole organism at one dose (the size of the read-out at that dose, not a potency): 32.8%
Beside the measured number, compound 3's estimate is 0.2 percentage points above it; the range from low to high includes it.
By their numbers in this assay, from the lowest: compounds 1, 3 and 2 (each within the scatter of the next).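

In this assay, (tert-butyl)amino in place of diethylamino on a carbonyl carbon brings in a hydrogen-bond donor and gives a number 4.7 percentage points lower from compound 2 to compound 3 (within the scatter), so the amide hydrogen does not set these two compounds apart. Tert-butyl in place of methyl on an amide-type nitrogen, with the amide hydrogen kept, gives a number 3.1 percentage points higher from compound 1 to compound 3 (within the scatter), so these two substituents cannot be told apart on this read-out either. All three amides therefore lie within the scatter of one another, and no measured evidence bears on this result.

Open, on these data alone, is whether any group on this carbonyl carbon gives a step beyond the scatter, for example piperidine as the amine part or a hydroxyl in place of the amine, which would make a carboxylic acid. Also open, as far as these compounds go, is whether the three amides stay this close at doses other than the one given.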